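This account rests on a few compounds, and the source may have more. Where it says the series, first, only, none or still open, it means among the compounds named here.

Compound 1 `COc1ccc2ncc(S(=O)(=O)c3cccc(Cl)c3)c(N3CCC(C)CC3)c2c1`: -3%
Compound 2 `COc1ccc2ncc(S(=O)(=O)c3ccc(F)cc3)c(N3CCC(C)CC3)c2c1`: 27%

Going by the values given here, in an assay on isolated protein for displacement of a labelled ligand from metabotropic glutamate receptor 5 (Homo sapiens), with a stated time of 60 min, tested at 1 uM (a lower number here means less inhibition, a higher number more inhibition at the concentration tested (going by the name of the read-out)), compound 2 stands highest of the two measured numbers, with compound 1 the nearer and lower one; the only measured step is a number 30 percentage points higher from compound 1 to compound 2 (beyond the scatter), a modest gain that lies beyond the scatter. Compound 3 `COc1ccc2ncc(S(=O)(=O)c3ccc(OC)c(Cl)c3)c(N3CCC(C)CC3)c2c1` differs from compound 2 by 3-chloro-4-methoxyphenyl in place of 4-fluorophenyl on a sulfonyl sulfur. Among the compounds with values here, the step from compound 1 to compound 2 bears on this only loosely: it also swapped the ring on the sulfonyl sulfur, exchanging 3-chlorophenyl for 4-fluorophenyl, and compound 3 now returns to a ring bearing chlorine while adding a methoxy group, a combination no measured pair covers. Within the data shown here, with no direct precedent, the expected step of a number 7 percentage points lower from compound 2 to compound 3 (within the scatter) is small and uncertain, most likely within the scatter but possibly a modest loss. Compound 3 is therefore estimated at 20%, within -5% to 45%.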

Compound 3, a percentage reported as inhibition, at one concentration (the size of the read-out at that concentration, not a potency): 21%
Compound 3: middle estimate off by 1 percentage points, on the low side; measured number inside the range.
By their numbers in this assay, from the lowest: compound 1; then compounds 3 and 2 (each within the scatter of the next).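

Placing 3-chloro-4-methoxyphenyl on the sulfonyl sulfur in place of 4-fluorophenyl gives a number 6 percentage points lower from compound 2 to compound 3 (within the scatter) and so leaves the reading unresolved, even though the entering group is larger and carries a hydrogen-bond acceptor. The more informative comparison is methoxy in place of hydrogen on an aromatic carbon of the chlorine-bearing ring, which gives a number 24 percentage points higher from compound 1 to compound 3 (beyond the scatter) and shows that a ring with chlorine need not sit at the low end of this short series. Nothing available here explains either step.

From the compounds shown here alone, whether methoxy would have the same effect on a ring without chlorine remains open, as does the result of a longer chain such as ethoxy, or of an amine, in its place. All three compounds share the rest of their structure, so the effect of changes elsewhere is also unknown.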